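A Selenium Swap on a Shared Core

The source may report more compounds than this note shows. Statements on the series, on what has been measured and on what is new or still open speak of the compounds shown alone.

Compound 1 `CSc1nc(NCCCc2ccccc2)c2ccccc2n1` and compound 2 `Sc1nc(NCc2ccccc2)c2ccccc2n1` were both tested in a functional assay on HTB-54 cells (Homo sapiens) for cytotoxicity, read by MTT assay, with a stated time of 72 h; a lower number here means a stronger inhibitor of growth, a higher number a weaker inhibitor of growth. For compound 1 the result is only a limit of the assay, > 100000 nM. For compound 2 the result is likewise a limit, > 100000 nM. The two results sit at the limit of > 100000 nM in this assay, at which 2 of the 2 values shown sit, so compound 2 has no number to rank it. Compound 3 `C[Se]c1nc(NCc2ccccc2)c2ccccc2n1` differs from compound 2 by a group of 2 heavy atoms (1 carbon, 1 selenium; no ring) in place of one sulfur atom, on an aromatic carbon. Among the measured compounds shown here, with no measured step to guide it, the change is expected to bring a step that the limit leaves unreadable from compound 2 to compound 3, not beyond the scatter. Compound 3 is therefore expected to give 200000 nM in this assay, between 50000 nM and 800000 nM.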

Compound 3, concentration for total growth inhibition: > 100000 nM
Compound 3: only a limit was reported; the forecaster's own chance of this, stated with the estimate: 75%; the middle value is on the limit's open side.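

Among the compounds shown here, compound 2 and compound 3 both end at a limit of the assay and not at a number, so no step between them can be read: the limit of > 100000 nM in this assay, at which 3 of the 3 values shown sit. The compounds shown leave open whether this change of group alters growth inhibition at all.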